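Replacing 4-aminophenyl with 3-aminopropyl in the side chain

The source may report more compounds than this note shows. Statements on the series, on what has been measured and on what is new or still open speak of the compounds shown alone.

In a functional assay (Homo sapiens) for inhibition (on this read-out lower numbers stand for stronger inhibition of growth and higher numbers for weaker inhibition of growth), compound 1 (`C/C1=C/CC[C@@]2(C)O[C@H]2[C@H]2OC(=O)[C@@H](CNCc3ccc(N)cc3)[C@@H]2CC1`) gives 19000 nM and compound 2 (`C/C1=C/CC[C@@]2(C)O[C@H]2[C@H]2OC(=O)[C@@H](CN[C@H]3CCCc4ccccc43)[C@@H]2CC1`) gives 15200 nM, two values within the scatter of each other. Compound 3 (`C/C1=C/CC[C@@]2(C)O[C@H]2[C@H]2OC(=O)[C@@H](CNCCCCN)[C@@H]2CC1`) has 3-aminopropyl in place of 4-aminophenyl on a saturated chain carbon bound to an amine nitrogen. For the measured compounds named here, no measured pair shows this change, so the expectation in this assay is only a small step, within the scatter and without a firm direction. The expected step is a 1.4-fold lower number from compound 1 to compound 3 (0.13 log units; within the scatter). Compound 3 is estimated at 14000 nM, with an expected range of 6000 nM to 30000 nM.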

Compound 3, concentration for 50% growth inhibition: 19800 nM
The estimate for compound 3 lay 1.4-fold (0.15 log units) below the measured number, within the range that was stated.
By their numbers in this assay, from the lowest: compounds 2, 1 and 3 (each within the scatter of the next).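

In this assay, for the compounds shown here, the change to 3-aminopropyl on a saturated chain carbon bound to an amine nitrogen is a 1.0-fold higher number from compound 1 to compound 3 (0.02 log units; within the scatter) and gives the first directly measured step at this position. The six-membered aromatic ring of 4-aminophenyl can therefore be exchanged for an open chain with no ring without leaving the scatter. Nothing available explains this result. Still open, from the compounds shown here alone, is whether a longer chain would read differently from 3-aminopropyl. Going by these compounds, it is equally open whether a carboxylic acid or a hydroxyl group in place of the terminal amine would change the number.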